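Amine swap at the anilide nitrogen of compound 3

The source may report more compounds than this note shows. Statements on the series, on what has been measured and on what is new or still open speak of the compounds shown alone.

Compound 3 `CCCN(CCC)c1ccc(C(=O)N2CCc3ccc(OS(N)(=O)=O)cc3C2)cc1` holds the lowest of the three numbers in an assay on HEK293 cells for inhibition of Steryl-sulfatase (Homo sapiens), tested at 1 uM (a higher number here means a stronger effect of the compound at the concentration tested, a lower number a weaker effect), giving 84.7%. Compound 1 `CC(C)CCN(CCC(C)C)c1ccc(C(=O)N2CCc3ccc(OS(N)(=O)=O)cc3C2)cc1` gives 90.8% in this assay, and compound 2 `CCN(Cc1ccc(Br)cc1)c1ccc(C(=O)N2CCc3ccc(OS(N)(=O)=O)cc3C2)cc1` gives 95.9%. The two steps that reach compound 3 are a number 6.1 percentage points lower from compound 1 to compound 3 (within the scatter) and a number 11.2 percentage points lower from compound 2 to compound 3 (beyond the scatter), so the three amines on the aromatic carbon all leave inhibition high. Compound 4 `CN(CCCN1CCCCC1)c1ccc(C(=O)N2CCc3ccc(OS(N)(=O)=O)cc3C2)cc1` differs from compound 3 by methyl(3-(piperidin-1-yl)propyl)amino in place of dipropylamino on an aromatic carbon. Among the compounds with values here, no measured step exchanges a dialkylamino for a chain bearing a second nitrogen in a ring, so the bearing of the earlier steps is only indirect: the swaps between dialkyl and benzyl-alkyl amines moved the read-out by a few points to a modest amount. A step of similar size at most is therefore expected, with no clear direction, and the estimate keeps compound 4 near its neighbours. For compound 4 the expected value in this assay is 85%, with a range from 68% to 96%, which means an expected step of a number 0.3 percentage points higher from compound 3 to compound 4 (within the scatter).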

Compound 4, a percentage reported as inhibition, at one concentration (the size of the read-out at that concentration, not a potency): 40.7%
Compound 4: middle estimate off by 44.3 percentage points, on the high side; measured number outside the range, below it.
By their numbers in this assay, from the lowest: compound 4; then compounds 3, 1 and 2 (each within the scatter of the next, the first and the last beyond it).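

Methyl(3-(piperidin-1-yl)propyl)amino is the first amine on this aromatic carbon to take away much of the read-out in this assay, with a number 44 percentage points lower from compound 3 to compound 4 (beyond the scatter) and a number 55.2 percentage points lower from compound 2 to compound 4 (beyond the scatter) and a number 50.1 percentage points lower from compound 1 to compound 4 (beyond the scatter) as its steps. High inhibition across dipropylamino, diisopentylamino and (4-bromobenzyl)(ethyl)amino therefore does not extend to every amine here, and the entering group brings a non-aromatic ring and a second nitrogen that none of those three carries. Nothing measured here accounts for the drop.

Going by these compounds, the ring, the second nitrogen and the methyl on the aniline nitrogen all change together in this one step, so their separate shares remain open. On these data alone, the read-out with a 3-cyclohexylpropyl chain or a 3-morpholinopropyl chain in place of the 3-(piperidin-1-yl)propyl chain also remains open.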